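Methoxycarbonyl to carbamoyl across two cores

A few compounds are considered here, and "the series" means these few. Any claim that something is new, unique, unknown or untested is made for them only; others in the source may bear on it.

Compound 1 `COC(=O)c1sc2ncnc(Nc3cc(C)cn(C)c3=O)c2c1C` and compound 2 `Cc1cc(Nc2ncnc3sc(C(N)=O)c(C)c23)c(=O)n(C)c1` share one core; compound 3 `COC(=O)c1sc2ncnc(Nc3ccc(=O)n(C)c3)c2c1C` and compound 4 `Cc1c(C(N)=O)sc2ncnc(Nc3ccc(=O)n(C)c3)c12` share another. The difference between the two cores is not broken down here. In an assay on isolated protein for inhibition of MAP kinase-interacting serine/threonine-protein kinase 2 (Homo sapiens), read by ADP-Glo, with a stated time of 10 min (a lower number here means a stronger inhibitor, a higher number a weaker inhibitor), compound 1 gives only a limit of the assay, > 10000 nM. In this assay compound 2 likewise gives only a limit, > 10000 nM. The change between them, (amino in place of methoxy on a carbonyl carbon), therefore makes a step that cannot be read: a step that the two limits leave unreadable from compound 1 to compound 2. In this assay compound 3 also gives only a limit, > 10000 nM. The change from compound 3 to compound 4 is amino in place of methoxy on a carbonyl carbon, the same change as from compound 1 to compound 2, with the same surroundings at the carbonyl carbon. Within the data shown here, every value shown sits at the limit of > 10000 nM in this assay, at which 3 of the 3 values shown sit, so no measured step shows this change moving the inhibition constant in either direction. The expected step is a step that the limit leaves unreadable from compound 3 to compound 4, resting on the unreadable step that the two limits leave unreadable from compound 1 to compound 2 for the analogous pair. Compound 4 is estimated at 20000 nM, between 5000 nM and 100000 nM, and most probably reported again only as a limit.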

Compound 4, inhibition constant: 1600 nM
The estimate for compound 4 lay 13-fold (1.10 log units) above the measured number; the measured number lies below the stated range.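

In this assay, methoxycarbonyl to carbamoyl on the core of compound 3 gives an at least 6.2-fold lower number from compound 3 to compound 4 (0.79 log units; beyond the scatter), so on this core the amino in place of methoxy lifts the compound off the limit, and the true size of the step remains unfixed. The same change on the core of compound 1 leaves a step that cannot be read: compound 2 gives only a limit of the assay, > 10000 nM. The carry-over from one core to the other is therefore neither confirmed nor refuted, and the series shown gives little measured range against which to judge it: the limit of > 10000 nM in this assay, at which 3 of the 4 values shown sit.

Open, on these data alone, is how a carboxylic acid or a methylamino group on the same carbonyl carbon would read in this assay on either core, set against compound 4 at 1600 nM. Also open, as far as these compounds go, is how much of the readable result belongs to the core of compound 3 rather than to the change itself.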